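The source may report more compounds than this note shows. Statements on the series, on what has been measured and on what is new or still open speak of the compounds shown alone.

In an ADME assay on S9 fraction from liver (Rattus norvegicus) for metabolic stability, read by LC-MS, using NADPH, with a stated time of 30 min (a lower number here means that less of the compound is left, a higher number that more of the compound is left), compound 1 (`CCCCCCCCc1ccc(OCC(=O)Cn2ncnn2)cc1`) reports < 5%, which is a limit of the assay and not a number. Within the data shown here, compound 2 (`CCCCCCCCc1ccc(OCC(=O)Cn2nnc(-c3ccccc3)n2)cc1`) gives 33%, the only actual number so far. Among the measured compounds shown here, the single measured step, a number at least 28 percentage points higher from compound 1 to compound 2 (beyond the scatter), came with phenyl in place of hydrogen on an aromatic carbon. Compound 3 (`CCCCCCCCc1ccc(OCC(=O)Cn2nnc(-c3cccc(Cl)c3)n2)cc1`) has chloro in place of hydrogen on an aromatic carbon, meta to a large group, turning phenyl into 3-chlorophenyl: chloro in place of hydrogen on an aromatic carbon. That earlier step is only a loose guide, since one step cannot show what a chloro does here. The starting point is therefore compound 2 at 33%, and no clear move in either direction is expected. The expected step is a number 2 percentage points higher from compound 2 to compound 3 (within the scatter), estimated to stay within the scatter. Compound 3 is expected at 35%, with an estimated range from 18% to 55%.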

Compound 3, percent of the compound remaining: 69%
Estimate against measurement, compound 3: 34 percentage points below, and the stated range ends below it.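

The earlier compounds shown here showed only that adding a phenyl raises the read-out in this assay. The change from phenyl to 3-chlorophenyl shows that this outer ring can still shift the result, as one chloro gives a number 36 percentage points higher from compound 2 to compound 3 (beyond the scatter) and so a large step from a single added atom, while 3-chlorophenyl in place of hydrogen gives a number at least 64 percentage points higher from compound 1 to compound 3 (beyond the scatter) overall. Compound 1 gives < 5%, which is a limit and not a number, so the overall step has only a lower end: the limit of < 5% in this assay, at which 1 of the 3 values shown sits.

Still open, as far as these compounds go, is whether fluoro, methyl or methoxy would do the same as chloro on this ring, or whether chloro would do the same at another place on it. Why the number rises, and which part of the molecule is lost during the assay, cannot be read from these values.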